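The source may hold more compounds than are shown below. What is called first, only, known or untested is meant among the compounds shown, and "the series" means these compounds.

Measured compounds:
- compound 1, `CNC(=O)CSc1nc2ccc(NC(=O)c3ccccc3OC)cc2s1`: 18500 nM
- compound 2, `CNC(=O)CSc1nc2ccc(NC(=O)CCl)cc2s1`: 1900 nM
- compound 3, `O=C(CSc1nc2ccc(NC(=O)CCl)cc2s1)NCc1ccc(Cl)cc1`: 1800 nM

All three were run in a functional assay on HepG2 cells (Homo sapiens) for cytotoxicity, read by MTT assay, with a stated time of 48 h; a lower number here means a stronger inhibitor, a higher number a weaker inhibitor. Compound 2 gives 1900 nM and compound 3 gives 1800 nM; the step of a 1.1-fold lower number from compound 2 to compound 3 (0.02 log units; within the scatter) is within the scatter, so no order between the two is claimed. The structural difference between their cores is 4-chlorophenyl in place of hydrogen on a saturated chain carbon bound to an amide-type nitrogen.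

Compound 1 differs from compound 2 by 2-methoxyphenyl in place of chloromethyl on a carbonyl carbon, and this change produced the step of a 9.7-fold higher number from compound 2 to compound 1 (0.99 log units; beyond the scatter), a modest shift toward a weaker inhibitor.

Compound 4, `COc1ccccc1C(=O)Nc1ccc2nc(SCC(=O)NCc3ccc(Cl)cc3)sc2c1`, is not yet measured. It differs from compound 3 by 2-methoxyphenyl in place of chloromethyl on a carbonyl carbon. The place line for this change reads the same, word for word, as the one from compound 2 to compound 1, so it counts as the same change, seen here for the second time among these compounds.

The expected step in this assay from compound 3 to compound 4 is estimated as a 9.4-fold higher number from compound 3 to compound 4 (0.98 log units; beyond the scatter), resting on the single earlier case a 9.7-fold higher number from compound 2 to compound 1 (0.99 log units; beyond the scatter) in a core that differs only by 4-chlorophenyl in place of hydrogen on a saturated chain carbon bound to an amide-type nitrogen. Since that core difference gave a step within the scatter, the earlier step is carried over as it stands. Compound 4 is therefore expected at 17000 nM, estimated within 7000 nM to 40000 nM.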

Compound 4, half-maximal inhibitory concentration: 600 nM
Compound 4: middle estimate off by 28-fold (1.45 log units), on the high side; the whole stated range lies above it.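

In this assay the new step is a 3.0-fold lower number from compound 3 to compound 4 (0.48 log units; beyond the scatter) and so runs opposite to the earlier case, which means that 2-methoxyphenyl in place of chloromethyl on a carbonyl carbon does not carry over between these two cores: the same change on two cores in this assay, a 9.7-fold higher number (0.99 log units; beyond the scatter) from compound 2 to compound 1 and a 3.0-fold lower number (0.48 log units; beyond the scatter) from compound 3 to compound 4, 29-fold (1.47 log units) apart, beyond the scatter of two such steps.

Read along the other edge of the same four compounds, 4-chlorophenyl in place of hydrogen on a saturated chain carbon bound to an amide-type nitrogen gives a 31-fold lower number from compound 1 to compound 4 (1.49 log units; beyond the scatter) when 2-methoxyphenyl is present, so the outcome of each change depends on the other: the same change on two cores in this assay, a 1.1-fold lower number (0.02 log units; within the scatter) from compound 2 to compound 3 and a 31-fold lower number (1.49 log units; beyond the scatter) from compound 1 to compound 4, 29-fold (1.47 log units) apart, beyond the scatter of two such steps.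

This shows that the two changes are not additive in this set, but it does not show why, and a single set of four compounds gives no rule for any other core.

Still open, on these data alone, is whether the reversal holds for other groups on the carbonyl carbon, such as unsubstituted phenyl or bromomethyl. Also open, as far as these compounds go, is how other groups on the amide-type nitrogen, such as a longer chain or a chain ending in an amine, would behave with each of the two acyl groups.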